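Difluoromethoxy on the benzyl ring of compound 1

A few compounds are considered here, and "the series" means these few. Any claim that something is new, unique, unknown or untested is made for them only; others in the source may bear on it.

Within the data shown here, compound 1 `COc1ccc2nc(C)cc(NCc3ccccc3)c2c1` has the lower of the two numbers measured so far in a functional assay on MCF-10A cells (Homo sapiens) for antiproliferative activity, with a stated time of 48 h; on this read-out lower numbers stand for an effect already at smaller amounts and higher numbers for an effect only at larger amounts of compound; compound 1 gives 25900 nM, and compound 2 `COc1ccc2nc(C)cc(NCc3cccnc3)c2c1` gives 44800 nM, a step of a 1.7-fold higher number from compound 1 to compound 2 (0.24 log units; within the scatter). Compound 3 `COc1ccc2nc(C)cc(NCc3cccc(OC(F)F)c3)c2c1` differs from compound 1 by difluoromethoxy in place of hydrogen on an aromatic carbon. Among the measured compounds shown here, no measured step touches this kind of change; the only step, from phenyl to pyridin-3-yl, stayed within the scatter, which suggests that changes on this ring leave this assay little moved. A step of about a 1.3-fold lower number from compound 1 to compound 3 (0.11 log units; within the scatter) is therefore expected, and compound 3 is estimated at 20000 nM, ranging from 8000 nM to 50000 nM.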

Compound 3, half-maximal effective concentration: 10300 nM
Compound 3: the middle estimate sits 1.9-fold (0.29 log units) above what was measured; the range from low to high includes it.
By their numbers in this assay, from the lowest: compound 3; then compounds 1 and 2 (each within the scatter of the next).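

Difluoromethoxy on an aromatic carbon, meta to a large group, gives the first change in this assay that lies beyond the scatter (a 2.5-fold lower number from compound 1 to compound 3 (0.40 log units; beyond the scatter)). This shows that the number can respond to a change on this side of the molecule, whereas replacing phenyl with pyridin-3-yl did not move it beyond the scatter (a 1.7-fold higher number from compound 1 to compound 2 (0.24 log units; within the scatter)). No evidence at hand explains the lower number.

As far as these compounds go, it remains open whether this result is specific to difluoromethoxy or would also appear with another group, such as an amine or a chlorine atom, on the same carbon. From the compounds shown here alone, it is also open whether difluoromethoxy would have the same effect on a different carbon of this ring.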